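Chain length of the ester and platelet inhibition

A few compounds are considered here, and "the series" means these few. Any claim that something is new, unique, unknown or untested is made for them only; others in the source may bear on it.

Measured compounds:
compound 1 `C/C=C/C(=O)Oc1cc2c(s1)CCN([C@H](C(=O)OC)c1ccccc1Cl)C2` 50.2%
compound 2 `CC/C=C/C(=O)Oc1cc2c(s1)CCN([C@H](C(=O)OC)c1ccccc1Cl)C2` 38.2%

In a functional assay on the whole organism (Platelet) for inhibition, with Rattus norvegicus as the target, at a dose of 1 mg/kg (a higher number here means a stronger effect of the compound at the dose given, a lower number a weaker effect), compound 1 gives 50.2%, and compound 2 gives 38.2%, the lower of the two numbers. Within the data shown here, the single step between them, a number 12 percentage points lower from compound 1 to compound 2 (beyond the scatter), lengthens the unsaturated ester chain.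

Compound 3 `CCC/C=C/C(=O)Oc1cc2c(s1)CCN([C@H](C(=O)OC)c1ccccc1Cl)C2` extends that chain once more: methyl in place of hydrogen on a saturated chain carbon, two bonds along the chain from a double-bonded chain carbon. Among the measured compounds shown here, only that step bears on it, and it was modest, so a further small decrease in this assay is expected, a number 8.2 percentage points lower from compound 2 to compound 3 (within the scatter), within or near the scatter. Compound 3 is estimated at 30%, in the range 15% to 45%.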

Compound 3, a percentage reported as inhibition, in the whole organism at one dose (the size of the read-out at that dose, not a potency): 52.8%
Estimate against measurement, compound 3: 22.8 percentage points below; measured number above the stated range.
By their numbers in this assay, from the lowest: compound 2; then compounds 1 and 3 (each within the scatter of the next).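

In this assay the added methyl, two bonds along the chain from a double-bonded chain carbon, gives a number 14.6 percentage points higher from compound 2 to compound 3 (beyond the scatter) and so runs opposite to the earlier step. With a number 2.6 percentage points higher from compound 1 to compound 3 (within the scatter) for ethyl in place of hydrogen on the saturated chain carbon bound to a double-bonded chain carbon, these three compounds show no steady trend with chain length, and compound 2 is the one that breaks any such line. No evidence here accounts for this turn. Going by these compounds, whether a longer chain would hold this level remains open, as does the effect of an amine or a carboxylic acid on the chain.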